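Chloro Removal on the Pendant Phenyl: Series Notes

This account rests on a few compounds, and the source may have more. Where it says the series, first, only, none or still open, it means among the compounds named here.

Compound 1 `COc1cc(/C=C/C(=O)C2=C(/C=C/c3ccc(O)c(OC)c3)NC(=O)NC2c2ccccc2)ccc1O`, compound 2 `COc1cc(/C=C/C(=O)C2=C(/C=C/c3ccc(O)c(OC)c3)NC(=O)NC2c2ccccc2Cl)ccc1O` and compound 3 `COc1cc(/C=C/C(=O)C2=C(/C=C/c3ccc(O)c(OC)c3)NC(=S)NC2c2c(Cl)cccc2Cl)ccc1O` have been measured in a functional assay on HCT-116 cells (Homo sapiens) for cytotoxicity, read by MTT assay, with a stated time of 48 h; on this read-out lower numbers stand for stronger inhibition and higher numbers for weaker inhibition. Compound 1 gives 25000 nM, compound 2 gives 50000 nM and compound 3 gives 50000 nM, so compound 3 stands level with compound 2 at the digits reported, and all three numbers lie within the scatter of one another. The difference between the cores of compound 2 and compound 3 is not broken down here. One change is measured: hydrogen in place of chloro on an aromatic carbon, which gave a 2.0-fold lower number from compound 2 to compound 1 (0.30 log units; within the scatter), a step within the scatter. Compound 4 `COc1cc(/C=C/C(=O)C2=C(/C=C/c3ccc(O)c(OC)c3)NC(=S)NC2c2ccccc2Cl)ccc1O` is not yet measured and differs from compound 3 by hydrogen in place of chloro on an aromatic carbon. This is the same kind of change, not the same one, since the place in compound 3 is also meta to a chloro group, whereas in compound 2 it is only ortho to a large group. For compound 4 the expected step in this assay is a 1.3-fold lower number from compound 3 to compound 4 (0.10 log units; within the scatter), set beside the earlier 2.0-fold lower number from compound 2 to compound 1 (0.30 log units; within the scatter). That expectation rests on compound 3 giving 50000 nM. Compound 4 is therefore estimated at 40000 nM, with a range from 15000 nM to 100000 nM.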

Compound 4, half-maximal inhibitory concentration: 100000 nM
Compound 4: middle estimate off by 2.5-fold (0.40 log units), on the low side; measured number inside the range.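

Hydrogen in place of chloro on an aromatic carbon gives a 2.0-fold higher number from compound 3 to compound 4 (0.30 log units; within the scatter) in this assay, and this step, read alone, says little about the change. Set beside the earlier step, however, the change does not carry over as a single value from the core of compound 2 to the core of compound 3: the same change on two cores in this assay, a 2.0-fold lower number (0.30 log units; within the scatter) from compound 2 to compound 1 and a 2.0-fold higher number (0.30 log units; within the scatter) from compound 3 to compound 4, 4.0-fold (0.60 log units) apart, beyond the scatter of two such steps. This does not show what separates the two steps, since the cores differ and the place in compound 3 is also meta to a chloro group, and two pairs set no rule for the series.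

Still open, on these data alone, is whether the gap between the steps belongs to the core or to the surroundings of the changed place on the phenyl ring. Also open, as far as these compounds go, is how fluoro, methoxy or an amine at that place would read on either core.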